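Ethoxy in place of butylamino on the shared core

This account rests on a few compounds, and the source may have more. Where it says the series, first, only, none or still open, it means among the compounds named here.

Compound 1 `COc1ccc2c(c1)NC(=O)CN2c1nc(OCC2CC2)nc2ccccc12` in a functional assay on KB cells (Homo sapiens) for inhibition, read by sulforhodamine B assay, with a stated time of 48 h; on this read-out higher numbers stand for weaker inhibition of growth and lower numbers for stronger inhibition of growth: 14.2 nM
Compound 2 `COc1ccc2c(c1)NC(=O)CN2c1nc(NCc2ccncc2)nc2ccccc12`: 7.5 nM
Compound 3 `CCCCNc1nc(N2CC(=O)Nc3cc(OC)ccc32)c2ccccc2n1`: 5.25 nM

Compound 3 gives the lowest number of the three, but only its separation from compound 1, a 2.7-fold lower number from compound 1 to compound 3 (0.43 log units; beyond the scatter), lies beyond the scatter; the gap to compound 2, a 1.4-fold lower number from compound 2 to compound 3 (0.15 log units; within the scatter), does not.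

Compound 4 `CCOc1nc(N2CC(=O)Nc3cc(OC)ccc32)c2ccccc2n1` is the next step: ethoxy in place of butylamino on an aromatic carbon. Among the compounds with values here, the one measured step that bears on it runs the other way, alkoxy to alkylamino, a 2.7-fold lower number from compound 1 to compound 3 (0.43 log units; beyond the scatter), a modest drop; an ethoxy group itself has not been tested. Reversing that step, compound 4 is expected to give a somewhat higher number, a 2.3-fold higher number from compound 3 to compound 4 (0.36 log units; beyond the scatter), with the estimate for compound 4 at 12 nM and a range of 5 nM to 30 nM.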

Compound 4, concentration for 50% growth inhibition: 11.6 nM
For compound 4 the middle estimate is 1.0-fold (0.01 log units) above the measured one; the measured number falls inside the stated range.
By their numbers in this assay, from the lowest: compounds 3, 2, 4 and 1 (each within the scatter of the next, the first and the last beyond it).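

In this assay, the swap from an alkylamino to an alkoxy group now has a second reading at this position between two ring nitrogen atoms: butylamino to ethoxy also costs growth inhibition (a 2.2-fold higher number from compound 3 to compound 4 (0.34 log units; beyond the scatter)), though the chain shortens and the donor is lost in the same change. The two alkoxy groups cannot be told apart (a 1.2-fold lower number from compound 1 to compound 4 (0.09 log units; within the scatter)), and compound 2 goes against a clean amino-over-alkoxy split (a 1.5-fold higher number from compound 2 to compound 4 (0.19 log units; within the scatter)). No measurement here explains the step.

Butoxy or ethylamino at this position would separate the linking atom from chain length.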